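Cyclopropylamino in place of 4-methylphenyl on the shared core

The compounds below may be only part of what the source reports. "The series", "measured", "known", "first", "only" and "open" are said of these compounds alone.

For the measured compounds named here, in an ADME assay on L1210/0 cells (Mus musculus) for cytotoxicity, with a stated time of 48 h (a lower number here means a stronger inhibitor, a higher number a weaker inhibitor), compound 1 `COc1ccc(-c2ncnc3c2ncn3C[C@@H]2C[C@H](CO)c3ccccc32)cc1` gives 17600 nM and compound 2 `Cc1ccc(-c2ncnc3c2ncn3C[C@@H]2C[C@H](CO)c3ccccc32)cc1` gives 15400 nM, so compound 2 stands within the scatter of the only other measured number. Compound 3 `OC[C@H]1C[C@@H](Cn2cnc3c(NC4CC4)ncnc32)c2ccccc21` differs from compound 2 by cyclopropylamino in place of 4-methylphenyl on an aromatic carbon. Going by the values given here, the only measured step, methyl in place of methoxy, is a 1.1-fold lower number from compound 1 to compound 2 (0.06 log units; within the scatter), and it leaves the six-membered aromatic ring in place. Among the compounds with values here, no measured step covers this replacement, so the expectation is weakly grounded. An expected step toward a higher number is a 2.6-fold higher number from compound 2 to compound 3 (0.41 log units; beyond the scatter). Compound 3 is estimated at 40000 nM, with an expected range of 10000 nM to 150000 nM.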

Compound 3, half-maximal inhibitory concentration: > 200000 nM
Compound 3: a limit, no number; the forecaster's own chance of this, stated with the estimate: 25%; at least 5.0-fold (0.69 log units) between middle value and limit.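

Exchanging methyl for methoxy on the six-membered aromatic ring stayed within the scatter, but replacing the whole 4-substituted phenyl group with cyclopropylamino on this aromatic carbon is a large change in this assay: an at least 12-fold higher number from compound 2 to compound 3 (1.11 log units; beyond the scatter), and an at least 11-fold higher number from compound 1 to compound 3 (1.05 log units; beyond the scatter). This position therefore responds strongly to this replacement, toward weaker inhibition. For compound 3 the result is a limit and not a number: the limit of > 200000 nM in this assay, at which 1 of the 3 values shown sits.

From the compounds shown here alone, whether the shift follows from losing the aromatic ring or from gaining the amine nitrogen remains open. Unsubstituted phenyl, benzylamino or a longer alkylamine chain on this carbon would help separate the two.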